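From compound 1 to compound 4: a methoxy step

The source may hold more compounds than are shown below. What is called first, only, known or untested is meant among the compounds shown, and "the series" means these compounds.

Compound 1 `CCN(CC)CN1C(=O)/C(=N/NC(=S)Nc2ccccc2)c2cc(Cl)ccc21`: 6900 nM
Compound 2 `CCN(CC)CN1C(=O)/C(=N/NC(=S)Nc2ccccc2)c2ccccc21`: 32300 nM
Compound 3 `CCN(CC)CN1C(=O)/C(=N/NC(=S)Nc2ccc(C)cc2)c2ccccc21`: 3800 nM

In an ADME assay on CRFK cells (Felis catus) for cytotoxicity (on this read-out lower numbers stand for higher toxicity in this test and higher numbers for lower toxicity in this test), compound 1 gives 6900 nM, within the scatter of compound 3 and well under compound 2. Compound 4 `CCN(CC)CN1C(=O)/C(=N/NC(=S)Nc2ccc(OC)cc2)c2cc(Cl)ccc21` keeps the core of compound 1 with one change: methoxy in place of hydrogen on an aromatic carbon. The nearest guide is the step of an 8.5-fold lower number from compound 2 to compound 3 (0.93 log units; beyond the scatter), methyl in place of hydrogen on an aromatic carbon. The step of a 4.7-fold higher number from compound 1 to compound 2 (0.67 log units; beyond the scatter) concerns the chloro, which compound 4 keeps, and offers less guidance. For the measured compounds named here, no methoxy compound has been measured, so a somewhat smaller step towards a lower number is expected, still beyond the scatter. The estimated step is a 2.9-fold lower number from compound 1 to compound 4 (0.46 log units; beyond the scatter). Compound 4 is estimated at 2400 nM, with an expected range of 700 nM to 7500 nM.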

Compound 4, half-maximal cytotoxic concentration: 3600 nM
For compound 4 the middle estimate is 1.5-fold (0.18 log units) below the measured one; measured number inside the range.
By their numbers in this assay, from the lowest: compounds 4, 3 and 1 (each within the scatter of the next); then compound 2.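

In this assay, methoxy in place of hydrogen on the anilino ring, para to a large group, gives a 1.9-fold lower number from compound 1 to compound 4 (0.28 log units; within the scatter), so with the chloro kept this change stays within the scatter. The methyl step without the chloro, an 8.5-fold lower number from compound 2 to compound 3 (0.93 log units; beyond the scatter), lies beyond it, but those two steps differ in both the entering group and the chloro, so neither difference can be singled out. Nothing at hand gives a reason for this result. Still open, as far as these compounds go, is how methoxy reads without the chloro, and how an amine or a carboxylic acid reads in the same place.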